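Dichlorination of the anilino ring in a chalcone series

This account rests on a few compounds, and the source may have more. Where it says the series, first, only, none or still open, it means among the compounds named here.

Compound 1, `COc1cccc(/C=C/C(=O)c2sc(Nc3ccccc3)nc2C)c1`: > 25000 nM
Compound 2, `Cc1nc(Nc2ccccc2)sc1C(=O)/C=C/c1ccccc1Cl`: > 25000 nM

Compound 1 was tested in a functional assay on PC-3 cells (Homo sapiens) for cytotoxicity, read by MTT assay; a lower number here means a stronger inhibitor, a higher number a weaker inhibitor. For compound 1 the result > 25000 nM is a limit of the assay, not a number. Compound 2 likewise gives in this assay only a limit, > 25000 nM. Among the compounds with values here, the single measured step, a step that the two limits leave unreadable from compound 1 to compound 2, therefore cannot be read in size or direction, since (the limit of > 25000 nM in this assay, at which 2 of the 2 values shown sit). Compound 3, `COc1cccc(/C=C/C(=O)c2sc(Nc3ccc(Cl)c(Cl)c3)nc2C)c1`, is not yet measured; it differs from compound 1 in that (3,4-dichlorophenyl in place of phenyl on a nitrogen on an aromatic ring). Within the data shown here, no measured step touches this position, and compound 1 itself stands only at a limit, so the data give no footing for any direction. The step of a number no higher from compound 1 to compound 3 (the limit leaves the size open) is expected to stay within the scatter. For compound 3 a value of 25000 nM is expected, between 8000 nM and 60000 nM, most likely again reported only as a limit.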

Compound 3, half-maximal inhibitory concentration: 10100 nM
Compound 3: middle estimate off by 2.5-fold (0.39 log units), on the high side; low and high end bracket the measured number.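

Within the data shown here, replacing phenyl with 3,4-dichlorophenyl on a nitrogen on an aromatic ring gives the first step in this assay that can be read, and it makes compound 3 a stronger inhibitor than compound 1 (an at least 2.4-fold lower number from compound 1 to compound 3 (0.39 log units; beyond the scatter)). This shows that the number responds to a change at this position, which the earlier pair could not show, as its step cannot be read. The size of the new step remains a floor rather than an exact figure because compound 1 stands only at a limit: the limit of > 25000 nM in this assay, at which 2 of the 3 values shown sit.

Still open, going by these compounds, is whether both chlorines are needed, and whether a trifluoromethyl group or an amine on this ring would move the number in the same way. Also open, on these data alone, is whether the same change would lower the number for compound 2.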